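Extending the Acetamide of Compound 1 Toward a Dipeptide

The compounds below may be only part of what the source reports. "The series", "measured", "known", "first", "only" and "open" are said of these compounds alone.

Compound 1, `CC(=O)N[C@H]1CCN(Cc2ccc(OCCCN(C)C)cc2)C1`: in an assay on HEK293 cells for binding affinity to Urotensin-2 receptor (Homo sapiens), read by radioligand binding (on this read-out lower numbers stand for stronger inhibition and higher numbers for weaker inhibition), compound 1 gives < 10000 nM
Compound 2, `CC(C)C[C@H](NC(=O)c1cc2ccccc2o1)C(=O)N[C@@H]1CCN(Cc2ccc(OCCCN(C)C)cc2)C1`: in this assay compound 2 gives < 10000 nM

Neither value is a number; each is a limit of the assay. Compound 1 therefore stands at the limit, and the same holds for compound 2, so that the limit of < 10000 nM in this assay, at which 2 of the 2 values shown sit, is the whole of what the measurements show. Among the measured compounds shown here, no step between measured compounds is available.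

Compound 3, `CC(=O)N[C@@H](CC(C)C)C(=O)N[C@H]1CCN(Cc2ccc(OCCCN(C)C)cc2)C1`, is to be measured in this assay. It differs from compound 1 in one place: 1-acetamido-3-methylbutyl in place of methyl on a carbonyl carbon. The 1-acetamido-3-methylbutyl group it gains is also part of compound 2, though compound 2 carries a larger group on that carbonyl carbon.

With only limits to go on, the step is expected to run toward stronger binding, a step that the limit leaves unreadable from compound 1 to compound 3, but with wide uncertainty. For compound 3 the estimate is 2000 nM, expected to fall between 200 nM and 10000 nM.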

Compound 3, inhibition constant: 2510 nM
Estimate against measurement, compound 3: 1.3-fold (0.10 log units) below; the measured number falls inside the stated range.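

In this assay, among the compounds shown here, compound 1 gives < 10000 nM, which is a limit of the assay and not a number, so no step from compound 1 to compound 3 can be read. From the compounds shown here alone, whether 1-acetamido-3-methylbutyl in place of methyl strengthens binding, and by how much, stays open.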